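A Pyridin-2-yl Swap Beside One Measured Compound

The source may hold more compounds than are shown below. What is called first, only, known or untested is meant among the compounds shown, and "the series" means these compounds.

Within the data shown here, in an ADME assay on liver (Macaca fascicularis) for metabolic stability, using microsomes, with a stated time of 10 min, tested at 0.5 uM (a higher number here means that more of the compound is left, a lower number that less of the compound is left), compound 2 `Cc1ccncc1-c1cccc2c1cnn2-c1ccccc1` gives 39% as the only number available. Compound 1 `Cc1ccncc1-c1cccc2c1cnn2-c1cccnn1` gives "not determined" (no result reported) and so offers no comparison. Compound 3 `Cc1ccncc1-c1cccc2c1cnn2-c1ccccn1` carries pyridin-2-yl in place of phenyl on an aromatic nitrogen and shares the rest of its structure with compound 2. Among the measured compounds shown here, no measured pair shows the size of such a change, so the expectation rests on the structural change alone. A moderate rise is expected in this assay with an estimated a number 13 percentage points higher from compound 2 to compound 3 (beyond the scatter) as its size. For compound 3 the expected value is 52% and the estimated range runs from 32% to 72% of the compound remaining.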

Compound 3, percent of the compound remaining: 19%
Estimate against measurement, compound 3: 33 percentage points above; the measured number lies below the stated range.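

At this aromatic nitrogen, pyridin-2-yl in place of phenyl gives a number 20 percentage points lower from compound 2 to compound 3 (beyond the scatter) in this assay. Among these compounds, this is the first measured size of a change at this position, and it shows that exchanging one ring carbon for nitrogen in this group is enough to shift the percentage of compound remaining beyond the scatter. Nothing available bears on why the number falls.

Open, from the compounds shown here alone, is how a pyridin-3-yl group or a saturated ring such as morpholine would fare at this position. Also open, going by these compounds, is whether the same swap would give a step of similar size on a different core.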